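The source may report more compounds than this note shows. Statements on the series, on what has been measured and on what is new or still open speak of the compounds shown alone.

The measured compounds in a functional assay on 786-0 cells (Homo sapiens) for inhibition, read by sulforhodamine B assay, with a stated time of 48 h; on this read-out lower numbers stand for stronger inhibition of growth and higher numbers for weaker inhibition of growth:

compound 1, `CC1=CC[C@H](C(C)(C)NC(=S)N/N=C/c2ccccc2)CC1`: 9900 nM
compound 2, `CC1=CC[C@H](C(C)(C)NC(=S)N/N=C/c2ccc(O)cc2)CC1`: > 100000 nM, which is a limit of the assay and not a number

Compound 1 holds the only number shown in this assay; the other value shown is a limit. The step of an at least 10-fold higher number from compound 1 to compound 2 (1.00 log units; beyond the scatter) is known only as a lower bound because the limit of > 100000 nM in this assay, at which 1 of the 2 values shown sits, caps what the assay reports.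

Compound 3, `CC1=CC[C@H](C(C)(C)NC(=S)N/N=C/c2ccccc2Cl)CC1`, differs from compound 1 by chloro in place of hydrogen on an aromatic carbon. For the measured compounds named here, the one measured step concerns a different group at a different place, so it bears on this change only loosely. Going by the values given here, no measured step speaks directly for the chloro group, so no shift beyond the scatter is expected in this assay, and the estimated step is a 1.0-fold higher number from compound 1 to compound 3 (0.00 log units; within the scatter). Compound 3 is therefore estimated at 10000 nM in this assay, with a range from 3000 nM to 40000 nM.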

Compound 3, concentration for 50% growth inhibition: 85500 nM
Compound 3: middle estimate off by 8.6-fold (0.93 log units), on the low side; the whole stated range lies below it.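

In this assay the phenyl ring of compound 1 turns out to be sensitive to a group other than hydroxy: chloro on an aromatic carbon, ortho to a large group, goes with much weaker inhibition of growth, seen as an 8.6-fold higher number from compound 1 to compound 3 (0.94 log units; beyond the scatter). Both substituted rings shown, the 2-chlorophenyl of compound 3 and the 4-hydroxyphenyl of compound 2, are therefore weaker than the plain phenyl of compound 1, although they carry different groups at different places. The two substituted rings cannot be ranked against each other, as the comparison gives only an at least 1.1-fold lower number from compound 2 to compound 3 (0.06 log units; that floor lies within the scatter): the limit of > 100000 nM in this assay, at which 1 of the 3 values shown sits.

From the compounds shown here alone, it remains open whether chloro at another place on the ring would cost as much. Going by these compounds, it is also open whether a methoxy group or an amine on this ring would hold the level of compound 1.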